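The compounds below may be only part of what the source reports. "The series", "measured", "known", "first", "only" and "open" are said of these compounds alone.

Of the compounds shown here, three sharing one core have been tested so far in a functional assay on HeLa cells (Homo sapiens) for cytotoxicity, read by MTT assay, with a stated time of 48 h; a higher number here means a weaker inhibitor, a lower number a stronger inhibitor. Compound 1 `COc1cc(/C=C/C(=O)C2=C(/C=C/c3ccc(O)c(OC)c3)NC(=O)NC2c2ccc(O)cc2)ccc1O` gives 25000 nM and compound 2 `COc1cc(/C=C/C(=O)C2=C(/C=C/c3ccc(O)c(OC)c3)NC(=O)NC2c2ccc(N(C)C)cc2)ccc1O` gives 25000 nM, which amounts to no change at the digits printed from compound 1 to compound 2 (within the scatter). Compound 3 `COc1cc(/C=C/C(=O)C2=C(/C=C/c3ccc(O)c(OC)c3)NC(=O)NC2c2cccc([N+](=O)[O-])c2)ccc1O` gives 100000 nM, the highest number of the three and so the weakest inhibitor in the set. The next compound, compound 4 `COc1cc(/C=C/C(=O)C2=C(/C=C/c3ccc(O)c(OC)c3)NC(=O)NC2c2ccccc2Cl)ccc1O`, carries 2-chlorophenyl in place of 3-nitrophenyl on a saturated ring carbon. For the measured compounds named here, no measured step brings in 2-chlorophenyl, so the evidence is indirect. Going by the values given here, the steps that bear on the change are the two that bring in 3-nitrophenyl, namely a 4.0-fold higher number from compound 1 to compound 3 (0.60 log units; beyond the scatter) and a 4.0-fold higher number from compound 2 to compound 3 (0.60 log units; beyond the scatter). Leaving 3-nitrophenyl may therefore be expected to give back part of that modest rise, though the data cannot say how much. The expected change is a 2.5-fold lower number from compound 3 to compound 4 (0.40 log units; beyond the scatter), toward a lower number in this assay. Compound 4 is estimated at 40000 nM, with an expected range from 15000 nM to 100000 nM.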

Compound 4, half-maximal inhibitory concentration: 100000 nM
Compound 4: middle estimate off by 2.5-fold (0.40 log units), on the low side; low and high end bracket the measured number.
By their numbers in this assay, from the lowest: compounds 1 and 2 (each within the scatter of the next); then compounds 3 and 4 (each within the scatter of the next).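

In this assay the exchange on the saturated ring carbon gives no change at the digits printed from compound 3 to compound 4 (within the scatter) and so the higher number does not belong to 3-nitrophenyl alone. 2-Chlorophenyl gives a 4.0-fold higher number from compound 1 to compound 4 (0.60 log units; beyond the scatter) and a 4.0-fold higher number from compound 2 to compound 4 (0.60 log units; beyond the scatter) in the same measure, so these four compounds fall into two pairs: the 4-hydroxyphenyl and 4-(dimethylamino)phenyl compounds at the lower number and the 2-chlorophenyl and 3-nitrophenyl compounds at the higher, with none going against this split. No measurement here gives a reason for that split.

Whether the split follows the substituent itself or its place on the phenyl ring stays open, as no substituent appears at two places among these compounds. Also open, going by these compounds, is how an unsubstituted phenyl or a carboxylic acid on that ring would read in this assay at this carbon.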